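A few compounds are considered here, and "the series" means these few. Any claim that something is new, unique, unknown or untested is made for them only; others in the source may bear on it.

In a functional assay on A549 cells (Homo sapiens) for inhibition, read by sulforhodamine B assay, with a stated time of 72 h (a lower number here means a stronger inhibitor, a higher number a weaker inhibitor), three compounds sharing one core have been measured. Compound 1 (`CC1CN(C(=O)c2c(N)sc(-c3ccc(Cl)cc3)c2-c2ccc(Cl)cc2)CCN1`) gives 4930 nM, compound 2 (`CC1CCN(C(=O)c2c(N)sc(-c3ccc(Cl)cc3)c2-c2ccc(Cl)cc2)CC1`) gives 1750 nM, and compound 3 (`CC(C)(C)NC(=O)c1c(N)sc(-c2ccc(Cl)cc2)c1-c1ccc(Cl)cc1`) gives 8850 nM. Compound 3 therefore sits clearly above compound 2, while its gap to compound 1 lies within the scatter.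

Compound 4 (`Nc1sc(-c2ccc(Cl)cc2)c(-c2ccc(Cl)cc2)c1C(=O)N1CCC(=O)CC1=O`) keeps the core and changes only the group on the carbonyl carbon: 2,4-dioxopiperidin-1-yl in place of (tert-butyl)amino on a carbonyl carbon. In words, 2,4-dioxopiperidin-1-yl stands in place of (tert-butyl)amino.

The three measured steps all involve this same place. They are a 2.8-fold lower number from compound 1 to compound 2 (0.45 log units; beyond the scatter), a 1.8-fold higher number from compound 1 to compound 3 (0.25 log units; within the scatter) and a 5.1-fold higher number from compound 2 to compound 3 (0.70 log units; beyond the scatter). So swapping this group has so far moved the number only modestly, or not beyond the scatter. Going by the values given here, no measured compound carries the 2,4-dioxopiperidin-1-yl group, so its own contribution is unknown. Compound 1 at 4930 nM and compound 2 at 1750 nM both carry a ring here, and neither lies above compound 3, so a small move towards a lower number is the more likely direction in this assay. The estimated change is a 1.8-fold lower number from compound 3 to compound 4 (0.25 log units; within the scatter), and a larger move is not expected. For compound 4 the expected value is 5000 nM, with an estimated range of 1800 nM to 14000 nM.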

Compound 4, half-maximal inhibitory concentration: 4090 nM
Compound 4: the middle estimate sits 1.2-fold (0.09 log units) above what was measured, and the stated range covers the measured number.
By their numbers in this assay, from the lowest: compound 2; then compounds 4, 1 and 3 (each within the scatter of the next, the first and the last beyond it).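

In this assay the open-chain (tert-butyl)amino can give way to the ring of 2,4-dioxopiperidin-1-yl with a 2.2-fold lower number from compound 3 to compound 4 (0.34 log units; beyond the scatter) as the result, so losing the hydrogen-bond donor of the leaving group and adding two hydrogen-bond acceptors does not raise the number here, and a 1.2-fold lower number from compound 1 to compound 4 (0.08 log units; within the scatter) places this new ring level with the 3-methylpiperazin-1-yl of compound 1. A ring at this position does not by itself settle the number, however: a 2.3-fold higher number from compound 2 to compound 4 (0.37 log units; beyond the scatter) leaves the 4-methylpiperidin-1-yl of compound 2 as the strongest inhibitor of the four, and the step from compound 1 to compound 3 shows that one ring can also sit within the scatter of an open-chain group. Nothing available explains why these groups differ.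

From the compounds shown here alone, it remains open which part of the 2,4-dioxopiperidin-1-yl group matters, since a plain piperidin-1-yl ring or a ring with a single carbonyl would separate the ring from its two carbonyl groups. Going by these compounds, it is also open whether a morpholine ring or a longer amine chain on the same carbonyl carbon would give a number lower than that of compound 2.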